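Thiophen-3-yl for furan-3-yl: estimating compound 4

A few compounds are considered here, and "the series" means these few. Any claim that something is new, unique, unknown or untested is made for them only; others in the source may bear on it.

Going by the values given here, in a functional assay on CCRF-CEM cells (Homo sapiens), read by MTT assay, with a stated time of 72 h (a lower number here means a stronger inhibitor, a higher number a weaker inhibitor), compound 3 `CSc1ncnc2c1c(-c1ccoc1)cn2[C@@H]1O[C@H](CO)[C@@H](O)[C@H]1O` gives 14200 nM, the only number so far.

Compound 1 `COc1ncnc2c1c(-c1ccccc1)cn2[C@@H]1O[C@H](CO)[C@@H](O)[C@H]1O` gives > 20000 nM, which is a limit and not a number.

Compound 2 `C#Cc1cn([C@@H]2O[C@H](CO)[C@@H](O)[C@H]2O)c2ncnc(OC)c12` gives > 20000 nM, also a limit.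

The shared limit is recorded as the limit of > 20000 nM in this assay, at which 2 of the 3 values shown sit.

Compound 4 `CSc1ncnc2c1c(-c1ccsc1)cn2[C@@H]1O[C@H](CO)[C@@H](O)[C@H]1O` carries thiophen-3-yl in place of furan-3-yl on an aromatic carbon of the shared core: thiophen-3-yl in place of furan-3-yl on an aromatic carbon.

Among the compounds with values here, the only measured step is a step that the two limits leave unreadable from compound 1 to compound 2. Within the data shown here, it concerns a different exchange and offers no size to carry over, and no measured step covers this exchange.

In this assay no step beyond the scatter is therefore expected, in either direction. The expectation rests on compound 3 at 14200 nM.

The expected step is a 1.1-fold lower number from compound 3 to compound 4 (0.04 log units; within the scatter).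

For compound 4 the estimated value is 13000 nM, with an expected range from 5000 nM to 28000 nM.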

Compound 4, half-maximal inhibitory concentration: > 20000 nM
Compound 4 ended at the assay's limit (the forecaster's own chance of this, stated with the estimate: 25%); at least 1.5-fold (0.18 log units) between middle value and limit.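

At this aromatic carbon, thiophen-3-yl in place of furan-3-yl gives in this assay an at least 1.4-fold higher number from compound 3 to compound 4 (0.14 log units; that floor lies within the scatter), so the exchange has a floor and no measured size. Compound 4 gives > 20000 nM, which is a limit of the assay. Compound 3 therefore remains the only compound with a number, and the exchange of one five-membered aromatic ring with 1 hetero atom for the other does not yield a second one, leaving the series largely at its ceiling: the limit of > 20000 nM in this assay, at which 3 of the 4 values shown sit.

On these data alone, how far compound 4 lies past the limit stays open, and with it whether the exchange has any effect beyond the scatter. Also open, as far as these compounds go, is how an amine or a carboxylic acid carried on this aromatic carbon would read in this assay.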